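The source may hold more compounds than are shown below. What is called first, only, known or untested is meant among the compounds shown, and "the series" means these compounds.

Three measured compounds share one core. Compound 1 `NC[C@@H]1CCCc2cc(S(=O)(=O)c3cc[nH]c3)ccc21` gives 0.316 nM in an assay on isolated protein for displacement of a labelled ligand from 5-hydroxytryptamine receptor 6 (Homo sapiens); on this read-out higher numbers stand for weaker inhibition and lower numbers for stronger inhibition. Compound 2 `CN(C)S(=O)(=O)NC[C@@H]1CCCc2cc(S(=O)(=O)c3cccc(F)c3)ccc21` gives 2 nM in this assay, and compound 3 `O=S(=O)(c1cccc(F)c1)c1ccc2c(c1)CCC[C@H]2CNCCO` gives 0.126 nM in this assay, the lowest number of the three. Compound 4 `CN(C[C@@H]1CCCc2cc(S(=O)(=O)c3cccc(F)c3)ccc21)C(N)=O` is still to be measured; it differs from compound 3 by carbamoyl(methyl)amino in place of (2-hydroxyethyl)amino on a saturated chain carbon bound to a saturated ring carbon. Among the compounds with values here, the only single-point step seen so far concerns this same amine nitrogen, and because a 16-fold lower number from compound 2 to compound 3 (1.20 log units; beyond the scatter) was large, capping that nitrogen again, as in compound 2, is expected to push the number back up. The estimated step for compound 4 is a 12-fold higher number from compound 3 to compound 4 (1.08 log units; beyond the scatter). Compound 4 is therefore estimated at 1.5 nM, with a range from 0.4 nM to 5 nM.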

Compound 4, inhibition constant: 39.8 nM
For compound 4 the middle estimate is 27-fold (1.42 log units) below the measured one; the whole stated range lies below it.
By their numbers in this assay, from the lowest: compound 3; then compound 1; then compound 2; then compound 4.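

At this saturated chain carbon, the size of the change depends on which group caps the nitrogen, not merely on whether it is capped: carbamoyl(methyl)amino gives a 320-fold higher number from compound 3 to compound 4 (2.50 log units; beyond the scatter) and, against (dimethylsulfamoyl)amino, gives a 20-fold higher number from compound 2 to compound 4 (1.30 log units; beyond the scatter) in the same direction. Compound 4 thus has the highest number of the four. Nothing measured here accounts for the gap between these two capping groups. The compounds shown leave open whether the methyl or the carbamoyl carries the step; a plain methylamino group or an acetamide on that nitrogen would separate the two.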